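Alkylating a ring nitrogen of compound 1

This account rests on a few compounds, and the source may have more. Where it says the series, first, only, none or still open, it means among the compounds named here.

Measured so far in a functional assay on K562 cells (Homo sapiens) for antiproliferative activity, read by MTT assay, with a stated time of 48 h; a lower number here means a stronger inhibitor, a higher number a weaker inhibitor:
compound 1, `Cn1cc(C2=C(c3n[nH]c4ncccc34)C(=O)NC2=O)c2ccccc21`, > 100000 nM
compound 2, `Cn1cc(C2=C(c3n[nH]c4ncccc34)C(=O)N(c3cccc4ccccc34)C2=O)c2ccccc21`, > 100000 nM
compound 3, `Cn1cc(C2=C(c3nn(CCCN4CCCCC4)c4ncccc34)C(=O)N(c3ccc(Cl)cc3)C2=O)c2ccccc21`, 1800 nM

Compound 1 gives only a limit in this assay, > 100000 nM. Compound 2 likewise stops at the limit > 100000 nM. Differing from compound 1 in two places, compound 3 gives 1800 nM. Among the measured compounds shown here, the single one-place step, a step that the two limits leave unreadable from compound 1 to compound 2, stays unreadable because the limit of > 100000 nM in this assay, at which 2 of the 3 values shown sit, caps both ends.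

Compound 4, `CN1CCN(CCCn2nc(C3=C(c4cn(C)c5ccccc45)C(=O)NC3=O)c3cccnc32)CC1`, differs from compound 1 as follows: 3-(4-methylpiperazin-1-yl)propyl in place of hydrogen on an aromatic nitrogen. For the measured compounds named here, no measured step covers this change. Among its two differences from compound 1 a chain on an aromatic nitrogen is also carried by compound 3, which gives 1800 nM. Compound 4 is therefore expected to move off the limit, estimated at 5000 nM (range 1000 nM to 30000 nM). The expected step of an at least 20-fold lower number from compound 1 to compound 4 (1.30 log units; beyond the scatter) starts from a limit and has no readable size.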

Compound 4, half-maximal inhibitory concentration: 46700 nM
Compound 4: middle estimate off by 9.3-fold (0.97 log units), on the low side; measured number outside the range, above it.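

In this assay, among the compounds shown here, 3-(4-methylpiperazin-1-yl)propyl on the aromatic nitrogen, as the only change to the core of compound 1, gives an at least 2.1-fold lower number from compound 1 to compound 4 (0.33 log units; beyond the scatter). This single substitution is enough to bring a measurable value, so this nitrogen accepts a large chain with the amide hydrogen left in place. The step gives only a minimum size, because compound 1 stands at a limit and not at a number: the limit of > 100000 nM in this assay, at which 2 of the 4 values shown sit.

Open, going by these compounds, is whether the piperazine ring itself matters, or whether a morpholine or a simple dimethylamine at the chain end would serve equally. A longer chain on this nitrogen also remains untested in the compounds shown.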